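Turning one ring stereocentre of compound 2

The source may report more compounds than this note shows. Statements on the series, on what has been measured and on what is new or still open speak of the compounds shown alone.

Compound 1, `O=C(NO)c1ccc(-c2cn([C@@H]3C[C@@H](C(=O)O)N(Cc4ccccc4)C3)nn2)cc1`, in an assay on Sf9 cells for inhibition of histone deacetylase 11 (Homo sapiens), read by fluorescence, tested at 0.5 uM (a lower number here means less inhibition, a higher number more inhibition at the concentration tested (going by the name of the read-out)), gives a value that is a limit of the assay, < 10%.
Compound 2, `O=C(/C=C/c1cn([C@H]2C[C@@H](CO)N(Cc3ccccc3)C2)nn1)NO`, gives 35% in this assay.
Compound 3, `O=C(NO)c1cccc(-c2cn([C@H]3C[C@@H](C(=O)O)N(CCCc4ccccc4)C3)nn2)c1`, gives in this assay a limit of the assay, < 10%.

Among the three measured compounds, compound 2 is the only one that yields an actual number in this assay; the other two sit at the limit of < 10% in this assay, at which 2 of the 3 values shown sit. Compound 4, `O=C(/C=C/c1cn([C@H]2C[C@H](CO)N(Cc3ccccc3)C2)nn1)NO`, has not yet been measured. It differs from compound 2 only in configuration: the two compounds have the same atoms and bonds and differ only in configuration as drawn: 1 of 3 stereo elements differ; a stereocentre at a saturated ring carbon is drawn S in compound 2 and R in compound 4. For the measured compounds named here, no measured pair in this set separates two compounds by a change in configuration alone, so nothing here shows how large such a step can be. The step from compound 2 to compound 4 is therefore expected to be modest, most likely a small loss, and possibly no larger than the usual scatter, so that a number 10 percentage points lower from compound 2 to compound 4 (within the scatter) is the estimated change. Compound 4 is expected to give about 25% in this assay, within a range from 5% to 45%.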

Compound 4, a percentage reported as inhibition, at one concentration (the size of the read-out at that concentration, not a potency): 20%
Compound 4: middle estimate off by 5 percentage points, on the high side; measured number inside the range.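

Turning this saturated ring carbon from S to R gives a number 15 percentage points lower from compound 2 to compound 4 (beyond the scatter), so in this assay the configuration at this position has a readable effect, which none of the earlier compounds could show. Compound 4 still gives a measured number, 20%, and not a limit, so the change lowers the reading without removing it. Nothing else separates the two structures, so the step belongs to this one stereocentre: the fact that compounds 2 and 4 differ only in the configuration as drawn

From the compounds shown here alone, whether the same inversion moves the reading as far once the alcohol gives way to an amine or an amide remains open, as does the contribution of the other ring stereocentre, which is drawn the same way in compound 2 and compound 4. A reading at a single concentration also leaves the potency of both compounds undefined.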